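Swapping the Heterocycle on a Weak Sulfonamide Series

A few compounds are considered here, and "the series" means these few. Any claim that something is new, unique, unknown or untested is made for them only; others in the source may bear on it.

Among the measured compounds shown here, compound 2, `Cc1cc(NS(=O)(=O)c2ccc(N/C(S)=N\c3ccnc4cc(C(F)(F)F)ccc34)cc2)on1`, stands at the weaker end of the two numbers measured so far. In a functional assay on AS49-RAW cells (Homo sapiens) for antiproliferative activity, read by sulforhodamine B assay, with a stated time of 48 h (a higher number here means a weaker inhibitor, a lower number a stronger inhibitor), compound 2 gives 60200 nM, while compound 1, `O=C(Nc1ccccc1)Nc1ccc(S(=O)(=O)Nc2ccnc3cc(C(F)(F)F)ccc23)cc1`, gives 24500 nM, a difference that lies beyond the usual scatter. Compound 3, `Cc1ccnc(NS(=O)(=O)c2ccc(N/C(S)=N\c3ccnc4cc(C(F)(F)F)ccc34)cc2)n1`, differs from compound 2 in one place: 4-methylpyrimidin-2-yl in place of 3-methyl-1,2-oxazol-5-yl on a sulfonamide nitrogen. For the measured compounds named here, no measured pair shows this change, so the step is expected to be small, likely within the scatter and with no clear direction. On that basis compound 3 is expected to give 50000 nM, within 20000 nM to 150000 nM, an expected step of a 1.2-fold lower number from compound 2 to compound 3 (0.08 log units; within the scatter).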

Compound 3, half-maximal inhibitory concentration: 31000 nM
Compound 3: middle estimate off by 1.6-fold (0.21 log units), on the high side; low and high end bracket the measured number.
By their numbers in this assay, from the lowest: compounds 1, 3 and 2 (each within the scatter of the next, the first and the last beyond it).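

The first step measured at this position is a 1.9-fold lower number from compound 2 to compound 3 (0.29 log units; within the scatter) in this assay and comes with 4-methylpyrimidin-2-yl in place of 3-methyl-1,2-oxazol-5-yl on a sulfonamide nitrogen. For this pair, a six-membered aromatic ring with 2 hetero atoms and a five-membered one give numbers that cannot be told apart. Nothing on hand explains this result.

The compounds shown leave open whether this nitrogen needs an aromatic ring at all, which a methyl group or a longer alkyl chain there would test. Going by these compounds, whether a plain phenyl ring would fit as well also remains unknown.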